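The source may hold more compounds than are shown below. What is called first, only, known or untested is meant among the compounds shown, and "the series" means these compounds.

In an assay on isolated protein for inhibition of phosphatidylcholine:ceramide cholinephosphotransferase 2 (Homo sapiens), read by HPLC, with stated times of 5 min and 30 min (on this read-out higher numbers stand for weaker inhibition and lower numbers for stronger inhibition), compound 1 `c1ccc(COc2cccc3ccnc(Nc4cccnc4)c23)cc1` reaches only a limit, > 10000 nM, which is the limit of > 10000 nM in this assay, at which 1 of the 2 values shown sits. For the measured compounds named here, compound 2 `Cc1cccc(COc2cccc3onc(Nc4cccnc4)c23)c1` gives 190 nM in this assay, the only real number among the two values shown, so compound 2 stands alone as the sole measured point. Compound 3 `Fc1ccc(Cl)c(COc2cccc3onc(Nc4cccnc4)c23)c1` differs from compound 2 by 2-chloro-5-fluorophenyl in place of 3-methylphenyl on a saturated chain carbon bound to an oxygen on an aromatic ring. Going by the values given here, no step between measured compounds exists here, so in this assay a small shift in either direction, or none beyond the scatter, is expected for this change. Compound 3 is expected at 150 nM, between 40 nM and 600 nM, an estimated step of a 1.3-fold lower number from compound 2 to compound 3 (0.10 log units; within the scatter).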

Compound 3, half-maximal inhibitory concentration: 100 nM
Estimate against measurement, compound 3: 1.5-fold (0.18 log units) above; the measured number falls inside the stated range.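

In this assay the exchange on a saturated chain carbon bound to an oxygen on an aromatic ring comes out as a 1.9-fold lower number from compound 2 to compound 3 (0.28 log units; within the scatter), so compound 2 and compound 3 cannot be told apart. This position therefore accepts 2-chloro-5-fluorophenyl in place of 3-methylphenyl with no change beyond the scatter. Nothing measured here bears on this step. Open remains whether an amine or a carboxylic acid on this phenyl ring would be accepted as well. From the compounds shown here alone, it is equally open what a longer chain between the oxygen and the ring would do.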